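The compounds below may be only part of what the source reports. "The series", "measured", "known", "first", "only" and "open" are said of these compounds alone.

Compound 1 `Cn1c(-c2ccc([N+](=O)[O-])cc2)nc2cc(C(F)(F)F)ccc21`; in an ADME assay on MDBK cells (Bos taurus) for cytotoxicity, read by MTT assay, with a stated time of 96 h (on this read-out lower numbers stand for higher toxicity in this test and higher numbers for lower toxicity in this test), compound 1 gives > 100000 nM, which is a limit of the assay and not a number.
Compound 2 `CC(=O)Nc1ccc(-c2nc3cc(C(F)(F)F)ccc3n2C)cc1`; in this assay compound 2 gives 46000 nM.

Compound 2 therefore supplies the only number shown in this assay; the one other value is a limit. Within the data shown here, the single measured step, an at least 2.1-fold lower number from compound 1 to compound 2 (0.33 log units; beyond the scatter), is bounded on one side by the limit of > 100000 nM in this assay, at which 1 of the 2 values shown sits, so only its lower size is known. Compound 3 `CCN(CC)CC(=O)Nc1ccc(-c2nc3cc(C(F)(F)F)ccc3n2C)cc1` differs from compound 2 by diethylamino in place of hydrogen on a saturated chain carbon bound to a carbonyl carbon. Among the measured compounds shown here, that step bears no likeness to the measured one, which changed a group on an aromatic carbon rather than on a saturated chain carbon bound to a carbonyl carbon, so no measured step shows the size or direction to expect. With nothing to point the other way, the expectation for compound 3 in this assay is a step of no change at the digits printed from compound 2 to compound 3 (within the scatter), within the scatter. Compound 3 is estimated at 46000 nM, with a range from 15000 nM to 140000 nM.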

Compound 3, half-maximal cytotoxic concentration: 57000 nM
Estimate against measurement, compound 3: 1.2-fold (0.09 log units) below; low and high end bracket the measured number.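

Compound 2 could not show whether the saturated chain carbon bound to a carbonyl carbon would accept anything larger than hydrogen. In this assay, diethylamino at that place gives a 1.2-fold higher number from compound 2 to compound 3 (0.09 log units; within the scatter), so this change leaves no mark on the read-out that can be told from ordinary repeat variation. Swapping nitro on an aromatic carbon for (((diethylamino)methyl)carbonyl)amino gives an at least 1.7-fold lower number from compound 1 to compound 3 (0.24 log units; that floor lies within the scatter), and so only a floor is known, one that does not separate the two compounds; compound 1 stands at a limit of the assay and not a number: the limit of > 100000 nM in this assay, at which 1 of the 3 values shown sits.

From the compounds shown here alone, whether diethylamino is a special case stays open, since a primary amine, morpholine or a carboxylic acid on the same carbon could read differently. Also open, going by these compounds, is whether a longer chain carrying the same amine would stay level with compound 2 in this assay.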